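A few compounds are considered here, and "the series" means these few. Any claim that something is new, unique, unknown or untested is made for them only; others in the source may bear on it.

Measured so far in a functional assay on NCI-H460 cells (Homo sapiens) for antiproliferative activity, read by MTT assay, with a stated time of 48 h; on this read-out lower numbers stand for stronger inhibition and higher numbers for weaker inhibition:
- compound 1 `COc1ccc(-c2nc3cccc(-c4cc(OC)c(OC)c(OC)c4)c3o2)cc1`: 3500 nM
- compound 2 `COc1cc(-c2cccc3nc(-c4ccc(F)cc4)oc23)cc(OC)c1OC`: 8700 nM
- compound 3 `COc1cc(-c2cccc3nc(-c4cccc(Br)c4)oc23)cc(OC)c1OC`: 3800 nM

Compound 3, at 3800 nM, stands level with compound 1, given a 1.1-fold higher number from compound 1 to compound 3 (0.04 log units; within the scatter), and clearly apart from compound 2, given a 2.3-fold lower number from compound 2 to compound 3 (0.36 log units; beyond the scatter). The next compound, compound 4 `COc1cc(-c2cccc3nc(-c4cccc(Cl)c4)oc23)cc(OC)c1OC`, changes one place of compound 3: chloro in place of bromo on an aromatic carbon. That is chloro in place of bromo on an aromatic carbon, meta to a large group.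

For the measured compounds named here, no measured pair makes this exact swap, so the evidence is indirect. Even the changes to the aromatic group on the shared core stayed small, with a 2.5-fold higher number from compound 1 to compound 2 (0.40 log units; beyond the scatter) and the two steps above. The swap from bromo to chloro alters a single atom, so no step beyond the scatter is expected in this assay. The expected change is a 1.1-fold higher number from compound 3 to compound 4 (0.02 log units; within the scatter). For compound 4 the estimated value is 4000 nM, with an expected range from 2000 nM to 8500 nM.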

Compound 4, half-maximal inhibitory concentration: > 25000 nM
Compound 4: a limit, no number (the forecaster's own chance of this, stated with the estimate: 3%); middle value at least 6.2-fold (0.79 log units) away from the limit.
By their numbers in this assay, from the lowest: compounds 1 and 3 (each within the scatter of the next); then compound 2. At a limit, above all of these: compound 4.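

In this assay compound 4 gives a limit of the assay and not a number: the limit of > 25000 nM in this assay, at which 1 of the 4 values shown sits. For the compounds shown here, exchanging bromo for chloro on this aromatic carbon, meta to a large group, gives an at least 6.5-fold higher number from compound 3 to compound 4 (0.81 log units; beyond the scatter), so a single-atom change at this position can matter far more than the earlier steps on the shared core suggested. Compound 4 also stands apart from the other two compounds, with an at least 2.8-fold higher number from compound 2 to compound 4 (0.45 log units; beyond the scatter) and an at least 7.1-fold higher number from compound 1 to compound 4 (0.85 log units; beyond the scatter), so here 3-chlorophenyl does not behave like 3-bromophenyl, 4-fluorophenyl or 4-methoxyphenyl.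

The limit leaves open how large these steps really are, and the compounds shown give no reason for the gap. On these data alone, it also remains open whether another group at this place, such as an amine, a nitrile or a methyl, would track with bromo or with chloro.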